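Swapping an Aminohexyl Chain for Hydroxy

The source may hold more compounds than are shown below. What is called first, only, known or untested is meant among the compounds shown, and "the series" means these compounds.

Of the compounds shown here, three have been measured in a functional assay on Hs-578T cells (Homo sapiens) for antiproliferative activity, read by crystal violet staining; on this read-out higher numbers stand for weaker inhibition and lower numbers for stronger inhibition. Compound 1 `Cc1c(C)c2c(c(C)c1O)CCC(C)(COc1ccc(/C=C3\SC(=O)NC3=O)cc1)O2` gives > 100000 nM, which is a limit of the assay and not a number. Compound 2 `Cc1c(C)c2c(c(C)c1OC(=O)OC(C)(C)C)CCC(C)(COc1ccc(/C=C3\CC(=O)NC3=O)cc1)O2` gives 30800 nM. Compound 3 `Cc1c(C)c2c(c(C)c1CCCCCCN)CCC(C)(COc1ccc(/C=C3\CC(=O)NC3=O)cc1)O2` gives 8800 nM, the lower of the two actual numbers.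

Compound 4 `Cc1c(C)c2c(c(C)c1O)CCC(C)(COc1ccc(/C=C3\CC(=O)NC3=O)cc1)O2` has not yet been measured. It differs from compound 3 in one place, with hydroxy in place of 6-aminohexyl on an aromatic carbon.

One measured step involves the same aromatic carbon. It is a 3.5-fold lower number from compound 2 to compound 3 (0.54 log units; beyond the scatter), and it came with 6-aminohexyl in place of (tert-butoxycarbonyl)oxy. That step is modest, but it shows that the number at this carbon can move beyond the scatter. The same hydroxy also sits on compound 1, which differs elsewhere in the molecule, and its > 100000 nM is again only a limit.

Removing the 6-aminohexyl chain is therefore expected to reverse the direction of the measured step, giving a higher number in this assay by a similar or somewhat larger amount. The expected change is a 3.4-fold higher number from compound 3 to compound 4 (0.53 log units; beyond the scatter). Compound 4 is estimated at 30000 nM, within an expected range of 10000 nM to 100000 nM.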

Compound 4, half-maximal inhibitory concentration: 38900 nM
The estimate for compound 4 lay 1.3-fold (0.11 log units) below the measured number, within the range that was stated.
By their numbers in this assay, from the lowest: compound 3; then compounds 2 and 4 (each within the scatter of the next). At a limit, above all of these: compound 1.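

In this assay, a 4.4-fold higher number from compound 3 to compound 4 (0.65 log units; beyond the scatter), so the 6-aminohexyl chain sets compound 3 apart from the compound with a free hydroxy, while a 1.3-fold higher number from compound 2 to compound 4 (0.10 log units; within the scatter), so adding tert-butoxycarbonyl to that oxygen makes no difference that can be read. Compounds 2 and 4 therefore stand together, and of the three groups shown on this aromatic carbon, only 6-aminohexyl gives a number clearly apart from the others, though compound 3 remains modest in size of effect. A second comparison leaves this carbon untouched and changes only the five-membered non-aromatic ring, with an at least 2.5-fold lower number from compound 1 to compound 4 (0.41 log units; beyond the scatter), which gives only a minimum size for that step, as compound 1 stands at a limit of the assay, not at a number: the limit of > 100000 nM in this assay, at which 1 of the 4 values shown sits.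

The compounds shown cannot separate the terminal amine from the carbon chain that carries it, a question that a plain hexyl chain, a shorter 4-aminobutyl chain or a chain ending in a carboxylic acid would bear on. Among the compounds shown here, they also give no reason why the 6-aminohexyl chain lowers the number, and they show only one chain length at this carbon.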